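A ring swap at the thiocarbonyl carbon

This account rests on a few compounds, and the source may have more. Where it says the series, first, only, none or still open, it means among the compounds named here.

Three compounds have been measured so far:
compound 1 `N/C(=N\NC(=S)N1CCN(c2ccccn2)CC1)c1ccc(F)cn1` gives 74.3% in a functional assay on MCF7 cells (Homo sapiens) for cytotoxicity, read by MTT assay, with a stated time of 72 h, tested at 100 uM; on this read-out higher numbers stand for more inhibition of growth at the one concentration tested and lower numbers for less inhibition of growth;
compound 2 `N/C(=N\NC(=S)N1CCCC1)c1ccc(F)cn1` gives 73% in this assay;
compound 3 `N/C(=N\NC(=S)N1CCCCC1)c1ccccn1` gives 77.7% in this assay.

The three numbers lie close together. Compound 2 carries the bottom number of the three, but its gap to compound 1 and its gap to compound 3 both fall within the usual scatter, so none of the three can be set apart from the others on this read-out. The ring on the thiocarbonyl carbon differs in each of them, and the numbers do not move beyond the scatter with it.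

Compound 4 `N/C(=N\NC(=S)N1CCSCC1)c1ccc(F)cn1` has not yet been measured. It differs from compound 2 in one place: thiomorpholin-4-yl in place of pyrrolidin-1-yl on a thiocarbonyl carbon. Since the change of ring from compound 2 to compound 3, and from compound 2 to compound 1, leaves the numbers within the scatter, a further change of ring at the same place is expected to do the same. The expected step from compound 2 to compound 4 is a number 1 percentage points higher from compound 2 to compound 4 (within the scatter), no more than the scatter and in no particular direction. For compound 4 the estimate in this assay is therefore 74%, with a range from 62% to 86%.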

Compound 4, percent growth inhibition at one concentration: 65.7%
Compound 4: the middle estimate sits 8.3 percentage points above what was measured, within the range that was stated.
By their numbers in this assay, from the lowest: compounds 4, 2, 1 and 3 (each within the scatter of the next, the first and the last beyond it).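

In this assay, thiomorpholin-4-yl in place of pyrrolidin-1-yl on a thiocarbonyl carbon gives a number 7.3 percentage points lower from compound 2 to compound 4 (within the scatter). This is the first pair shown that differs in one place, so it gives the first direct reading at this position, which the earlier compounds, with no such pair among them, could not give: going from a five-membered ring with one hetero atom to a six-membered ring with two, one of them sulfur, does not move the number beyond the scatter. No measurement at hand bears on why the number of compound 4 falls where it does.

The compounds shown leave open whether morpholin-4-yl, with oxygen where thiomorpholin-4-yl has sulfur, or an open-chain group such as dimethylamino would also stay within the scatter at this place on the thiocarbonyl carbon. Among the compounds shown here, they also leave open what the fluorine on the shared core contributes to this read-out, since the one step available concerns only the ring on the thiocarbonyl carbon.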